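The compounds below may be only part of what the source reports. "The series", "measured", "known", "first", "only" and "open" are said of these compounds alone.

Compounds measured so far:

Compound 1 `CCC(c1ccccc1)c1nc(-c2ccc(Cl)cc2)c(CC(=O)O)s1`: 50%
Compound 2 `O=C(O)Cc1sc(C(c2ccc(F)cc2)c2ccc(F)cc2)nc1-c1cc(F)cc(F)c1`: 80%
Compound 3 `O=C(O)Cc1sc(C(c2ccccc2)c2ccccc2)nc1-c1ccc(F)c(F)c1`: 80%

In an in vitro functional assay on HEK285-7 cells for antagonist activity at prostaglandin D2 receptor 2 (Homo sapiens), read by BRET and beta-arrestin recruitment (on this read-out higher numbers stand for larger maximal responses and lower numbers for smaller maximal responses), compound 2 gives 80%. Compound 3 reaches 80% in this assay, and the two stand level at the digits shown, within the scatter of each other; together they mark the highest of the three numbers. Compound 1, with 50%, lies clearly lower, beyond the scatter, and is the furthest from compound 2.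

Compound 4 `O=C(O)Cc1sc(C(c2ccc(F)cc2)c2ccc(F)cc2)nc1-c1cccc(F)c1` has not yet been measured. It differs from compound 2 in one place: hydrogen in place of fluoro on an aromatic carbon. Put one bond further out, the 3,5-difluorophenyl group of compound 2 becomes a 3-fluorophenyl group in compound 4; the fluoro leaves and a hydrogen enters on an aromatic carbon of a six-membered aromatic ring of carbon only.

Among the measured compounds shown here, no pair of measured compounds differs in a single place, so there is no measured step to set against this change. Compounds 2 and 3, which carry differently placed fluoro groups on that ring, show the same response; this points to a small step. The expected step of a number 5 percentage points lower from compound 2 to compound 4 (within the scatter) is small and within the scatter. Compound 4 is thus estimated at 75%, with a range from 55% to 95%.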

Compound 4, largest response reached (reported as efficacy), in percent of the reference or control that the assay uses: 80%
Estimate against measurement, compound 4: 5 percentage points below, within the range that was stated.
By their numbers in this assay, from the lowest: compound 1; then compounds 2, 3 and 4 (each within the scatter of the next).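

In this assay, among the compounds shown here, hydrogen in place of fluoro on an aromatic carbon, which turns the 3,5-difluorophenyl group into a 3-fluorophenyl group, gives no change at the digits printed from compound 2 to compound 4 (within the scatter), the first step in this set that changes a single place. The earlier compounds shown here offered no such pair, so only now can it be said that, at this carbon of the six-membered aromatic ring, meta to a fluoro group and meta to a large group, this read-out does not separate fluoro from hydrogen, with compound 4 giving 80% in this series. No measurement shown here gives a reason for this outcome.

The compounds shown leave open whether the response would hold if the remaining fluoro also gave way to hydrogen, leaving a plain phenyl group on the shared core. They also leave open what a methoxy group, a trifluoromethyl group or an amine at this same carbon would do, and whether the same exchange would read alike with other groups at the far end of the core.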